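The source may report more compounds than this note shows. Statements on the series, on what has been measured and on what is new or still open speak of the compounds shown alone.

Compound 1 `CC1=C(C(=O)SC(C)C)C(c2cccs2)NC(=O)N1` and compound 2 `CC1=C(C(=O)OC2CCCCC2)C(c2ccoc2)NC(=O)N1` share one core. In an assay on membranes from HEK293 cells for displacement of a labelled ligand from adenosine receptor A2b (Homo sapiens), read by scintillation counting, with a stated time of 30 min, tested at 1 uM (a lower number here means less inhibition, a higher number more inhibition at the concentration tested (going by the name of the read-out)), compound 1 gives 1%, and in this assay compound 2 gives 4%, a number that differs from that of compound 1 by less than the usual scatter. Compound 3 `CC1=C(C(=O)OC2CCCCC2)C(c2cccs2)NC(=O)N1` is compound 2 with thiophen-2-yl in place of furan-3-yl on a saturated ring carbon. Among the measured compounds shown here, no step between measured compounds is known here, and compound 1 carries the same thiophen-2-yl group at a low value. The step of a number 1 percentage points lower from compound 2 to compound 3 (within the scatter) is therefore expected to be nothing beyond the scatter. Compound 3 is estimated at 3%, between -5% and 12%.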

Compound 3, a percentage reported as inhibition, at one concentration (the size of the read-out at that concentration, not a potency): 3%
Estimate against measurement, compound 3: no gap at the digits printed, within the range that was stated.
By their numbers in this assay, from the lowest: compounds 1, 3 and 2 (each within the scatter of the next).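

In this assay placing thiophen-2-yl instead of furan-3-yl on the saturated ring carbon gives a number 1 percentage points lower from compound 2 to compound 3 (within the scatter) and so does not separate these two groups at this position. Cyclohexyloxy instead of isopropylsulfanyl on the carbonyl carbon gives a number 2 percentage points higher from compound 1 to compound 3 (within the scatter) and so leaves that second position equally unresolved. No evidence on the cause of these results is available here. Going by these compounds, whether an amine or a carboxylic acid on the saturated ring carbon, or a longer chain on the carbonyl carbon, would change the inhibition remains open.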